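A Methyl Added to the Ring Nitrogen of Compound 2

A few compounds are considered here, and "the series" means these few. Any claim that something is new, unique, unknown or untested is made for them only; others in the source may bear on it.

Two related compounds have been tested in a functional assay on KB 3-1 cells (Homo sapiens) for cytotoxicity, read by MTT assay, with a stated time of 72 h; on this read-out higher numbers stand for weaker inhibition and lower numbers for stronger inhibition. Compound 1 `O=C1/C(=C/c2cccnc2)CNC/C1=C\c1cccnc1` gives 24400 nM in this assay, while compound 2 `O=C1/C(=C/c2ccncc2)CNC/C1=C\c1ccncc1` gives 5000 nM. Among the measured compounds shown here, of these two numbers, the one for compound 2 is the lower, and its distance from the number for compound 1 lies beyond the usual scatter of this assay.

The next compound, compound 3 `CN1C/C(=C\c2ccncc2)C(=O)/C(=C/c2ccncc2)C1`, has not yet been measured. It differs from compound 2 in one place: methyl in place of hydrogen on an amine nitrogen in a ring. For the measured compounds named here, no pair of measured compounds shows what this particular change does, so the expected size of the step is uncertain. A small change of this kind is expected to move the number little, most likely by an amount that stays within the scatter, with a slight lean toward a higher number. Compound 3 is therefore estimated at 6000 nM, within a range from 2000 nM to 18000 nM, which would mean a step of a 1.2-fold higher number from compound 2 to compound 3 (0.08 log units; within the scatter).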

Compound 3, half-maximal inhibitory concentration: 3000 nM
Beside the measured number, compound 3's estimate is 2.0-fold (0.30 log units) above it; measured number inside the range.
By their numbers in this assay, from the lowest: compounds 3 and 2 (each within the scatter of the next); then compound 1.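

The change from hydrogen to methyl on the amine nitrogen in the ring gives a 1.7-fold lower number from compound 2 to compound 3 (0.22 log units; within the scatter) in this assay and offers no firm direction. Among the compounds shown here, both earlier compounds carry hydrogen at this place, so this is the first sign that the hydrogen on this nitrogen can give way to a methyl with no change this cytotoxicity read-out can separate from ordinary scatter. Nothing available explains why the number holds, so the result stands as an observation only.

Going by these compounds, one methyl says little about larger groups, and whether an ethyl, a benzyl or an acetyl on this nitrogen would keep the number in the same region remains open. Also open, on these data alone, is whether the same methyl would give a similar step on compound 1 .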